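Chain length and chloro removal in an adenosine series

The compounds below may be only part of what the source reports. "The series", "measured", "known", "first", "only" and "open" are said of these compounds alone.

Compound 1 `CCn1c(=O)[nH]c2c(cnn2-c2cccc(Cl)c2)c1=N`, compound 2 `CCCn1c(=O)[nH]c2c(cnn2-c2cccc(Cl)c2)c1=N` and compound 3 `CCCCn1c(=O)[nH]c2c(cnn2-c2cccc(Cl)c2)c1=N` share one core and differ only in the saturated chain attached to the aromatic nitrogen. In an assay on membranes from brain for binding affinity to adenosine receptor A1 (Rattus norvegicus), read by radioligand binding, tested at 20 uM (a lower number here means less inhibition, a higher number more inhibition at the concentration tested (going by the name of the read-out)), compound 1 gives 70%, compound 2 gives 68% and compound 3 gives 58%. Across the lengthening of that chain, a number 2 percentage points lower from compound 1 to compound 2 (within the scatter), a number 10 percentage points lower from compound 2 to compound 3 (within the scatter) and a number 12 percentage points lower from compound 1 to compound 3 (beyond the scatter). Compound 3 thus stands lowest of the three numbers, separated from compound 2 by a gap within the scatter and from compound 1 by a gap beyond it.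

Compound 4 `CCCCn1c(=O)[nH]c2c(cnn2-c2ccccc2)c1=N` keeps the chain of compound 3 and alters the six-membered aromatic ring of carbon only: hydrogen in place of chloro on an aromatic carbon. Among the compounds with values here, none of the three measured steps touches that ring; each of them changes only the chain on the aromatic nitrogen, so no measured step bears directly on this change. With nothing in the series to anchor a direction, the expected step is a number 8 percentage points lower from compound 3 to compound 4 (within the scatter), meaning no movement beyond the scatter but with wide uncertainty. Compound 4 is therefore estimated at 50% in this assay, with a range from 30% to 70%.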

Compound 4, a percentage reported as inhibition, at one concentration (the size of the read-out at that concentration, not a potency): 72%
Compound 4: the middle estimate sits 22 percentage points below what was measured, outside the stated range (above it).
By their numbers in this assay, from the lowest: compounds 3, 2, 1 and 4 (each within the scatter of the next, the first and the last beyond it).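

The 3-chlorophenyl to phenyl change is the first shown to touch the six-membered aromatic ring of carbon only, and with the chain held constant it gives a number 14 percentage points higher from compound 3 to compound 4 (beyond the scatter) as the read-out, so this position affects the result and loss of the chloro raises the number here. In this assay the chloro is therefore not required for inhibition at the tested concentration with this chain, since compound 4 gives 72% without it, and a ring change can shift the number about as much as the chain change giving a number 12 percentage points lower from compound 1 to compound 3 (beyond the scatter) in this set. Nothing available on these compounds explains the rise.

Open, going by these compounds, is whether hydrogen in place of chloro has the same effect on the shorter chains of compound 1 and compound 2, or whether it depends on the chain of compound 3. Also open, on these data alone, is how a fluoro, methoxy or amine group at this place on the ring would compare with hydrogen and chloro, and whether a longer chain than that of compound 4 would keep its number.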